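The compounds below may be only part of what the source reports. "The series", "measured", "known", "first", "only" and "open" are said of these compounds alone.

Compound 1 `C#CCSc1nc(Sc2nccs2)c(C#N)c(-c2ccc(Br)cc2)n1`: 3990 nM
Compound 2 `C#CCSc1nc(Sc2nc3ccccc3s2)c(C#N)c(-c2cc(OC)c(OC)c(OC)c2)n1`: > 20000 nM (a limit)
Compound 3 `C#CCSc1nc(Sc2nnnn2CCN(C)C)c(C#N)c(-c2cccc(Cl)c2)n1`: 8640 nM

These values come from a functional assay on SMMC-7721 cells (Homo sapiens) for antiproliferative activity, read by MTT assay, with a stated time of 72 h; on this read-out higher numbers stand for weaker inhibition and lower numbers for stronger inhibition. For compound 2 the entry > 20000 nM is a limit of the assay and not a number. Of the two true numbers, compound 1 holds the lower at 3990 nM. Compound 3 gives 8640 nM, a higher number by a margin beyond the usual scatter.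

Compound 4 `C#CCSc1nc(Sc2nccs2)c(C#N)c(-c2ccc[nH]2)n1` has not yet been measured. It carries 1H-pyrrol-2-yl in place of the 4-bromophenyl of compound 1 on an aromatic carbon of the shared core: 1H-pyrrol-2-yl in place of 4-bromophenyl on an aromatic carbon. Among the measured compounds shown here, no two measured compounds differ in only one place, so the data offer no direct guide to this change. For the measured compounds named here, compound 1 has the lowest number so far at 3990 nM, so a modest move towards weaker inhibition is expected, though a result within the scatter remains possible. The expected step is a 1.6-fold higher number from compound 1 to compound 4 (0.21 log units; within the scatter). Compound 4 is estimated at 6500 nM, with an expected range from 1800 nM to 20000 nM.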

Compound 4, half-maximal inhibitory concentration: > 20000 nM
Compound 4: a limit, no number; the forecaster's own chance of this, stated with the estimate: 15%; middle value at least 3.0-fold (0.48 log units) from the limit.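

In this assay, among the compounds shown here, placing 1H-pyrrol-2-yl instead of 4-bromophenyl on the aromatic carbon ortho to a cyano group gives the first comparison of compounds that differ in one place: an at least 5.0-fold higher number from compound 1 to compound 4 (0.70 log units; beyond the scatter). With the (1,3-thiazol-2-yl)sulfanyl and propargylsulfanyl groups unchanged, this position therefore responds clearly to this exchange, which replaces a six-membered carbon ring bearing bromine with a five-membered ring that has 1 hydrogen-bond donor. Compound 4 stands at a limit of this assay and not at a number, so the full size of this step stays unknown: the limit of > 20000 nM in this assay, at which 2 of the 4 values shown sit.

The pair does not separate the loss of the bromine from the change of ring or the entry of the donor. Going by these compounds, how a plain phenyl or a thienyl group would read at this position remains open.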